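Thiosemicarbazones on a shared core: a nitro analogue expected

A few compounds are considered here, and "the series" means these few. Any claim that something is new, unique, unknown or untested is made for them only; others in the source may bear on it.

Compound 1 `CC1=CC[C@H](C(C)(C)NC(=S)N/N=C/c2ccccc2)CC1` — in an ADME assay on Vero cells (Chlorocebus sabaeus) for inhibition, read by sulforhodamine B assay, with a stated time of 48 h (a lower number here means a stronger inhibitor of growth, a higher number a weaker inhibitor of growth), compound 1 gives > 100000 nM, which is a limit of the assay.
Compound 2 `CC1=CC[C@H](C(C)(C)NC(=S)N/N=C/c2ccc(N(C)C)cc2)CC1` — in this assay compound 2 gives > 100000 nM, also a limit.
Compound 3 `CC1=CC[C@H](C(C)(C)NC(=S)N/N=C/c2ccc(F)cc2)CC1` — in this assay compound 3 gives > 100000 nM, again a limit.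

Compound 1 therefore stands nowhere in particular on a scale of numbers: it sits at the limit of > 100000 nM in this assay, at which 3 of the 3 values shown sit. The step from compound 1 to compound 2, dimethylamino in place of hydrogen on an aromatic carbon, is a step that the two limits leave unreadable from compound 1 to compound 2. The step from compound 1 to compound 3, fluoro in place of hydrogen on an aromatic carbon, is a step that the two limits leave unreadable from compound 1 to compound 3. The step from compound 2 to compound 3 is likewise a step that the two limits leave unreadable from compound 2 to compound 3.

Compound 4 `CC1=CC[C@H](C(C)(C)NC(=S)N/N=C/c2cccc([N+](=O)[O-])c2)CC1` differs from compound 1 by nitro in place of hydrogen on an aromatic carbon. All three measured steps bear on this change, as each replaces a hydrogen on the same aromatic ring with another group, and none of them could be read, since every value sits at the limit. Among the measured compounds shown here, no step of any readable size, in either direction, is therefore expected in this assay; the expected outcome is a further limit. The expected step from compound 1 to compound 4 is accordingly a number no higher from compound 1 to compound 4 (the limit leaves the size open). For compound 4 the estimate in this assay is 100000 nM, with a range from 40000 nM to 250000 nM.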

Compound 4, concentration for total growth inhibition: > 100000 nM
Compound 4 ended at the assay's limit (the forecaster's own chance of this, stated with the estimate: 80%); the middle value sits exactly at the limit.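

The step from compound 1 to compound 4 cannot be read, since in this assay both compounds stand at the same limit, as do compound 2 and compound 3: the limit of > 100000 nM in this assay, at which 4 of the 4 values shown sit. The compounds shown leave open how far each lies from that limit, and whether any of these groups on the aromatic ring changes growth inhibition at all.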